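A few compounds are considered here, and "the series" means these few. Any claim that something is new, unique, unknown or untested is made for them only; others in the source may bear on it.

Measured so far in a functional assay on ECa-109 cells for inhibition, with ECa-109 cell line (Homo sapiens) as the target, read by sulforhodamine B assay; a lower number here means a stronger inhibitor, a higher number a weaker inhibitor:
compound 1 `O=C1C(Nc2ccc(Br)cc2)=CC(=O)c2c1nc1n2[C@H]2OC[C@@H](O)[C@H]2OC1`: 1980 nM
compound 2 `COc1cccc(NC2=CC(=O)c3c(nc4n3[C@H]3OC[C@@H](O)[C@H]3OC4)C2=O)c1`: 3340 nM

Compound 2 stands within the scatter of compound 1, so the pair gives no order. Among the compounds with values here, the one measured step is a 1.7-fold higher number from compound 1 to compound 2 (0.23 log units; within the scatter), with 3-methoxyphenyl in place of 4-bromophenyl on an amine nitrogen.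

Next is compound 3 `O=C1C(NC2CCCCC2)=CC(=O)c2c1nc1n2[C@H]2OC[C@@H](O)[C@H]2OC1`, with cyclohexyl in place of 3-methoxyphenyl on an amine nitrogen. Within the data shown here, no measured compound carries a non-aromatic ring at this place, so the single step bears on this change only loosely. The expectation therefore starts from compound 2 at 3340 nM, and no shift beyond the scatter is expected in this assay, with the range kept wide on both sides. The expected step is a 1.2-fold higher number from compound 2 to compound 3 (0.08 log units; within the scatter). Compound 3 is estimated at 4000 nM, with an expected range of 1500 nM to 12000 nM.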

Compound 3, half-maximal inhibitory concentration: > 16000 nM
Compound 3: a limit, no number; the forecaster's own chance of this, stated with the estimate: 10%; at least 4.0-fold (0.60 log units) between middle value and limit.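

In this assay compound 3 gives > 16000 nM, a limit and not a number. The amine nitrogen position proves sensitive to its substituent: cyclohexyl brings an at least 4.7-fold higher number from compound 2 to compound 3 (0.68 log units; beyond the scatter) and an at least 8.0-fold higher number from compound 1 to compound 3 (0.90 log units; beyond the scatter), whereas exchanging 4-bromophenyl for 3-methoxyphenyl stayed within the scatter, at a 1.7-fold higher number from compound 1 to compound 2 (0.23 log units; within the scatter). Among the three compounds, the only steps beyond the scatter are those that replace a six-membered aromatic ring of carbon only with a non-aromatic one.

Within the data shown here, with cyclohexyl as the only non-aromatic group, these steps do not show whether the aromatic ring itself matters or only the particular groups compared. Also open, on these data alone, is how an unsubstituted phenyl, a benzyl, a pyridyl or a short chain such as n-butyl on this nitrogen would read in this assay.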